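Swapping vinyl for prop-1-en-1-yl on the amide

The source may report more compounds than this note shows. Statements on the series, on what has been measured and on what is new or still open speak of the compounds shown alone.

Measured in a functional assay on A549 cells (Homo sapiens) for antiproliferative activity, read by MTT assay, with a stated time of 72 h; a lower number here means a stronger inhibitor, a higher number a weaker inhibitor:
Compound 1 `C/C=C/C(=O)Nc1cccc(Oc2nc(Nc3cccc(OC)c3)nc3c2CSCC3)c1` gives 21100 nM
Compound 2 `C/C=C/C(=O)Nc1cccc(Oc2nc(Nc3ccc(OC)cc3)nc3c2CSCC3)c1` gives 22200 nM
Compound 3 `C=CC(=O)Nc1cccc(Oc2nc(Nc3ccc(OC)nc3)nc3c2CSCC3)c1` gives 14600 nM

Compound 3 at 14600 nM sits within the scatter of both other values. Compound 4 `C/C=C/C(=O)Nc1cccc(Oc2nc(Nc3ccc(OC)nc3)nc3c2CSCC3)c1` carries prop-1-en-1-yl in place of vinyl on a carbonyl carbon. For the measured compounds named here, no measured step isolates this change. Going by the values given here, the one step available (a 1.1-fold higher number from compound 1 to compound 2 (0.02 log units; within the scatter)) concerns the methoxyphenyl group and lies within the scatter. Compound 1 at 21100 nM and compound 2 at 22200 nM already carry prop-1-en-1-yl and, though they also differ from compound 3 elsewhere, stay within the scatter of its value. In this assay no step beyond the scatter is therefore expected. The estimate means only a small step (a 1.2-fold higher number from compound 3 to compound 4 (0.09 log units; within the scatter)) at most. Compound 4 is estimated at 18000 nM with an expected range from 9000 nM to 36000 nM on repeated measurement.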

Compound 4, half-maximal inhibitory concentration: 8040 nM
Compound 4: the middle estimate sits 2.2-fold (0.35 log units) above what was measured; measured number outside the range, below it.
By their numbers in this assay, from the lowest: compounds 4, 3, 1 and 2 (each within the scatter of the next, the first and the last beyond it).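

For the compounds shown here, at the carbonyl carbon, prop-1-en-1-yl and vinyl cannot be told apart in this assay with a 1.8-fold lower number from compound 3 to compound 4 (0.26 log units; within the scatter) as the only direct step. With prop-1-en-1-yl held constant, the group on the nitrogen does register: 6-methoxypyridin-3-yl in place of 4-methoxyphenyl gives a 2.8-fold lower number from compound 2 to compound 4 (0.44 log units; beyond the scatter) and in place of 3-methoxyphenyl gives a 2.6-fold lower number from compound 1 to compound 4 (0.42 log units; beyond the scatter) as the only steps shown beyond the scatter. No available evidence accounts for these steps. On these data alone, it remains open whether the 6-methoxypyridin-3-yl step also holds with vinyl on the carbonyl carbon, and how an amine or a longer chain at that carbon would read.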